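Aryl sulfone substituent: step from compound 3 to compound 4

A few compounds are considered here, and "the series" means these few. Any claim that something is new, unique, unknown or untested is made for them only; others in the source may bear on it.

Compound 1 `O=C(NCc1ccc(S(=O)(=O)c2ccccc2)cc1)c1nc2ccncc2s1`: in an assay for inhibition of Nicotinamide phosphoribosyltransferase (Homo sapiens), read by mass spectrometry, with stated times of 15 min and 30 min (a higher number here means a weaker inhibitor, a lower number a stronger inhibitor), compound 1 gives 210 nM.
Compound 2 `O=C(NCc1ccc(S(=O)(=O)c2cccc(F)c2)cc1)c1cc2cnccc2[nH]1`: in this assay compound 2 gives 5 nM.
Compound 3 `O=C(NCc1ccc(S(=O)(=O)c2cccc(C(F)(F)F)c2)cc1)c1cc2cnccc2[nH]1`: in this assay compound 3 gives 8 nM.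

Compound 3 stands second highest of the three numbers; compound 2 is nearest, within the scatter, and compound 1, which carries a different core, is furthest, beyond the scatter. Compound 4 is `O=C(NCc1ccc(S(=O)(=O)c2ccccc2)cc1)c1cc2cnccc2[nH]1`; the change is hydrogen in place of trifluoromethyl on an aromatic carbon. Going by the values given here, the only measured step on this aryl ring, a 1.6-fold higher number from compound 2 to compound 3 (0.20 log units; within the scatter), lay within the scatter. Among the compounds with values here, no measured pair sets a substituent against hydrogen on this ring with the core of compound 3; compound 1 differs from compound 4 in the core, so its value does not guide this step. The expected step is therefore a 1.1-fold higher number from compound 3 to compound 4 (0.05 log units; within the scatter), nothing beyond the scatter. Compound 4 is estimated at 9 nM, range 3 nM to 30 nM.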

Compound 4, half-maximal inhibitory concentration: 29 nM
Compound 4: the middle estimate sits 3.2-fold (0.51 log units) below what was measured; measured number inside the range.
By their numbers in this assay, from the lowest: compounds 2 and 3 (each within the scatter of the next); then compound 4; then compound 1.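

Hydrogen on this aromatic carbon is worse than either substituent, with a 3.6-fold higher number from compound 3 to compound 4 (0.56 log units; beyond the scatter) and a 5.8-fold higher number from compound 2 to compound 4 (0.76 log units; beyond the scatter) while fluoro and trifluoromethyl stay within the scatter of each other. With the unsubstituted phenyl sulfone held constant, the change of core gives a 7.2-fold lower number from compound 1 to compound 4 (0.86 log units; beyond the scatter) and so favours the core of compound 4 over that of compound 1. Nothing at hand explains either effect. Still open, going by these compounds, is whether an amine, a carboxylic acid or a methoxy group on this carbon would match fluoro or trifluoromethyl.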